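The source may report more compounds than this note shows. Statements on the series, on what has been measured and on what is new or still open speak of the compounds shown alone.

Compound 1 `CCCCCCc1cn(C(c2ccccc2)c2cc3cc(Br)ccc3nc2OC)nn1` carries a hexyl chain on one of its rings, and in an ADME assay on HEK293 cells (Homo sapiens) for cytotoxicity, read by sulforhodamine B assay, with a stated time of 48 h, tested at 10 uM (a lower number here means less inhibition, a higher number more inhibition at the concentration tested (going by the name of the read-out)), compound 1 gives -3.17%, a number that means essentially no effect on the cells at the concentration tested. Among the measured compounds shown here, its only measured neighbour, compound 2 `CCOC(=O)c1cn(C(c2ccccc2)c2cc3cc(Br)ccc3nc2OC)nn1`, gives 2% in this assay; the two numbers sit within the scatter of each other, and the one step seen so far, a number 5.2 percentage points higher from compound 1 to compound 2 (within the scatter), is accordingly not a real change. Compound 1 thus stands among two numbers that both say the cells are left untouched.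

Compound 3 `COc1nc2ccc(Br)cc2cc1C(c1ccccc1)n1cc(CO)nn1` is the next member: hydroxy in place of pentyl on a saturated chain carbon bound to an aromatic carbon. This change sits on the saturated chain carbon rather than on the aromatic carbon that the measured step altered, so that step bears on it only in a general way, showing that a change at the chain end moved nothing beyond the scatter. With both measured compounds near zero, no step beyond the scatter is expected for compound 3 either, meaning a number 3.2 percentage points higher from compound 1 to compound 3 (within the scatter) in this assay. Compound 3 is therefore estimated at 0%, within the range -12% to 12%.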

Compound 3, a percentage reported as inhibition, at one concentration (the size of the read-out at that concentration, not a potency): 11.5%
Beside the measured number, compound 3's estimate is 11.5 percentage points below it; the range from low to high includes it.
By their numbers in this assay, from the lowest: compounds 1, 2 and 3 (each within the scatter of the next, the first and the last beyond it).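

Swapping the hexyl chain for hydroxymethyl produces the first step in this assay that clears the scatter, a number 14.7 percentage points higher from compound 1 to compound 3 (beyond the scatter), so a change at this aromatic carbon can shift the reading, if only modestly. Swapping ethoxycarbonyl for hydroxymethyl gives a number 9.5 percentage points higher from compound 2 to compound 3 (within the scatter), which stays within the scatter, so compound 2 cannot be separated from compound 3 any more than from compound 1, and only the two ends of this short series stand apart. Nothing measured here explains the difference between compound 1 and compound 3, although the counts show that the group entering brings a hydrogen-bond donor and the group leaving brings none.

Going by these compounds, it remains open whether an amine, a carboxylic acid or a longer chain ending in hydroxy at the same place would take the reading further from zero or return it to the level of compound 1. A reading at a single concentration also leaves open how inhibition by compound 3 would change at other concentrations, so its size here is not a measure of potency.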